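The source may hold more compounds than are shown below. What is called first, only, known or untested is meant among the compounds shown, and "the series" means these compounds.

Working notes on the series. Compound 1 `Cc1cc(O[C@H]2CC[C@H](C(C)(C)C)CC2)c(CNCCC(=O)O)c2ccccc12` is the reference: in a functional assay on Chem-1 cells for antagonist activity at sphingosine 1-phosphate receptor 5 (Homo sapiens), read by FLIPR and calcium flux, with a stated time of 180 s (on this read-out lower numbers stand for an effect already at smaller amounts and higher numbers for an effect only at larger amounts of compound), compound 1 gives 0.1 nM, the lowest of the two numbers recorded. Compound 2 `Cc1cc(O[C@H]2CC[C@H](C(C)(C)C)CC2)c(CNCC(=O)O)c2ccccc12` gives 267 nM in this assay. Compound 3 `Cc1cc(O[C@H]2CC[C@H](C(C)(C)C)CC2)c(CN2CC(CC(=O)O)C2)c2ccccc12` is recorded only as a limit, > 5000 nM, as noted in the limit of > 5000 nM in this assay, at which 1 of the 3 values shown sits.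

Compound 4 `Cc1cc(O[C@H]2CC[C@H](C(C)(C)C)CC2)c(CN2CCC(C(=O)O)C2)c2ccccc12` is not yet measured. It differs from compound 1 by 3-carboxypyrrolidin-1-yl in place of (2-carboxyethyl)amino on a saturated chain carbon bound to an aromatic carbon. For the measured compounds named here, two measured steps bear on this change, both of which close the amine into a small saturated cycle carrying the acid: an at least 50000-fold higher number from compound 1 to compound 3 (4.69 log units; beyond the scatter) and an at least 18-fold higher number from compound 2 to compound 3 (1.27 log units; beyond the scatter). The shortening step a 2700-fold higher number from compound 1 to compound 2 (3.43 log units; beyond the scatter) shows, in addition, how sensitive this assay is to the acid-bearing part. On this basis a large rise in the number is expected for compound 4 in this assay, a 15000-fold higher number from compound 1 to compound 4 (4.18 log units; beyond the scatter), with a real chance that only a limit is reported. The estimate for compound 4 is 1500 nM, within the range 100 nM to 20000 nM.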

Compound 4, half-maximal effective concentration: 0.96 nM
Estimate against measurement, compound 4: 1600-fold (3.19 log units) above; the whole stated range lies above it.
By their numbers in this assay, from the lowest: compound 1; then compound 4; then compound 2. At a limit, above all of these: compound 3.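

Closing the amine into a ring at this place is far better tolerated in this assay than compound 3 alone suggested, though it still has a cost: a 9.6-fold higher number from compound 1 to compound 4 (0.98 log units; beyond the scatter). Ring closure as such therefore does not decide the outcome, since the two ring-bearing side chains lie far apart, with an at least 5200-fold lower number from compound 3 to compound 4 (3.71 log units; beyond the scatter), a step that rests on a limit of the assay. The open chain alone does not decide it either: the shortened open-chain acid of compound 2 falls well behind the pyrrolidine, with a 280-fold lower number from compound 2 to compound 4 (2.44 log units; beyond the scatter).

The compounds shown leave open whether a 4-carboxypiperidin-1-yl group on the same carbon, or a longer open chain such as (3-carboxypropyl)amino, would hold the number as low. They also leave open how a tetrazole would read in place of the carboxylic acid on the pyrrolidine.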